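Working notes on a small ester series in paw edema

The source may hold more compounds than are shown below. What is called first, only, known or untested is meant among the compounds shown, and "the series" means these compounds.

Measured so far:
compound 1 `CCOC(=O)C(=O)Nc1ccccc(C)c1=O` — 34%
compound 2 `CCOC(=O)C(=O)Nc1ccc(OC)ccc1=O` — 53%

Among the compounds with values here, in a functional assay on the whole organism (strain Sprague-Dawley CD) for inhibition, with Rattus norvegicus as the target, read by paw edema, at a dose of 100 mg/kg by the oral route (on this read-out higher numbers stand for a stronger effect at the one dose given and lower numbers for a weaker effect), compound 2 gives 53%, the higher of the two values measured so far. Compound 1 gives 34%, and the gap between the two compounds is beyond the scatter. Within the data shown here, the two measured compounds differ in more than one place, so no single step between them can be read from their values, and neither value can be tied to one structural feature.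

Compound 3 `CCOC(=O)C(=O)Nc1ccc(NC(=O)C(=O)OCC)c(=O)cc1` has not yet been measured. Against compound 2 the change is ((ethoxycarbonyl)carbonyl)amino in place of methoxy on an aromatic carbon. Among the measured compounds shown here, no measured pair shows this change, so the expectation rests only on where compound 2 stands. A step of a number 13 percentage points lower from compound 2 to compound 3 (beyond the scatter) is expected, modestly downward, though a result within the scatter would not surprise. Compound 3 is therefore estimated to give 40%, with a range from 15% to 65%.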

Compound 3, a percentage reported as inhibition, in the whole organism at one dose (the size of the read-out at that dose, not a potency): 76%
Estimate against measurement, compound 3: 36 percentage points below; measured number outside the range, above it.
By their numbers in this assay, from the lowest: compound 1; then compound 2; then compound 3.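

This position on the seven-membered aromatic ring, three ring bonds from the ring atom that bears a group of 8 heavy atoms, accepts far more than methoxy: in this assay the ((ethoxycarbonyl)carbonyl)amino group, with 8 heavy atoms against 2, gives a number 23 percentage points higher from compound 2 to compound 3 (beyond the scatter). Within the data shown here, this is the first single change that can be read, and the effect at the one dose rises rather than being lost with the larger group. Nothing measured on these compounds explains the step.

The compounds shown leave open which part of ((ethoxycarbonyl)carbonyl)amino carries the step, as its size, amide hydrogen and carbonyl groups all enter together. A plain amine at this position, or a carboxylic acid in place of the ethyl ester, would begin to separate these parts.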